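Ring expansion at the oxalamide: compound 2 to compound 3

The compounds below may be only part of what the source reports. "The series", "measured", "known", "first", "only" and "open" are said of these compounds alone.

In a functional assay on MDA-MB-231 cells (Homo sapiens) for cytotoxicity, read by MTT assay, with a stated time of 72 h (on this read-out lower numbers stand for stronger inhibition and higher numbers for weaker inhibition), compound 2 `COc1ccc(/C(=C(/CCNC(=O)C(=O)N2CCCC2)c2ccccc2)c2ccccc2)cc1` gives 48600 nM, the higher of the two numbers in hand; compound 1 `COc1ccc(/C(=C(/CCNC(=O)C(=O)NCc2ccccc2)c2ccccc2)c2ccccc2)cc1` gives 11500 nM. Among the measured compounds shown here, the only measured step, a 4.2-fold higher number from compound 1 to compound 2 (0.63 log units; beyond the scatter), concerns a different replacement on the same carbonyl carbon. Compound 3 `COc1ccc(/C(=C(/CCNC(=O)C(=O)N2CCCCC2)c2ccccc2)c2ccccc2)cc1` differs from compound 2 by piperidin-1-yl in place of pyrrolidin-1-yl on a carbonyl carbon. For the measured compounds named here, no measured pair tests such a ring enlargement, so the author expects a step of a 1.2-fold lower number from compound 2 to compound 3 (0.08 log units; within the scatter), within the scatter, and estimates for compound 3 a value of 40000 nM, between 15000 nM and 110000 nM.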

Compound 3, half-maximal inhibitory concentration: > 50000 nM
Compound 3 was reported as a limit; the forecaster's own chance of this, stated with the estimate: 15%; middle value at least 1.2-fold (0.09 log units) from the limit.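

In this assay compound 3 gives only a limit, not a number: the limit of > 50000 nM in this assay, at which 1 of the 3 values shown sits.

The ring enlargement reads as an at least 1.0-fold higher number from compound 2 to compound 3 (0.01 log units; that floor lies within the scatter), so the data do not settle whether piperidin-1-yl differs from pyrrolidin-1-yl on this carbonyl carbon. The comparison with benzylamino is firmer, at an at least 4.3-fold higher number from compound 1 to compound 3 (0.63 log units; beyond the scatter), and both ring-bearing compounds now give higher numbers than compound 1.

Still open, as far as these compounds go, is how far compound 3 lies past its limit. Also open, from the compounds shown here alone, is whether a morpholine ring, or a phenethylamino chain in place of benzylamino, would bring the number towards that of compound 1.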